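A Second Acetyl on the Amide Nitrogen of Compound 2

The compounds below may be only part of what the source reports. "The series", "measured", "known", "first", "only" and "open" are said of these compounds alone.

Compound 1 `COc1ccc(-c2c(-c3cc(OC)c(OC)c(OC)c3)noc2NC(C)=O)cc1OC`: > 50000 nM (a limit)
Compound 2 `COc1cc(-c2noc(NC(C)=O)c2-c2ccc(Cl)cc2)cc(OC)c1OC`: 1910 nM

Within the data shown here, in a functional assay on PC-3 cells (Homo sapiens) for cytotoxicity, read by MTT assay, with a stated time of 48 h (on this read-out higher numbers stand for weaker inhibition and lower numbers for stronger inhibition), compound 2 gives 1910 nM, the only actual number so far. For compound 1 the result of > 50000 nM is a limit, not a number.

Compound 3 `COc1cc(-c2noc(N(C(C)=O)C(C)=O)c2-c2ccc(Cl)cc2)cc(OC)c1OC` differs from compound 2 in one place: acetyl in place of hydrogen on an amide-type nitrogen. An acetyl takes the place of hydrogen on an amide-type nitrogen, turning acetamido into diacetylamino.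

Among the measured compounds shown here, the only measured step, an at least 26-fold lower number from compound 1 to compound 2 (1.41 log units; beyond the scatter), is large, but it puts 4-chlorophenyl in place of 3,4-dimethoxyphenyl on an aromatic carbon and leaves that nitrogen untouched. For the measured compounds named here, no measured pair tests a change at this nitrogen, so the guide is weak and the range must be wide. No step beyond the scatter is expected in this assay. The expected step is a 1.0-fold higher number from compound 2 to compound 3 (0.02 log units; within the scatter). Compound 3 is estimated at 2000 nM, with an expected range from 500 nM to 8000 nM.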

Compound 3, half-maximal inhibitory concentration: 2630 nM
Beside the measured number, compound 3's estimate is 1.3-fold (0.12 log units) below it, and the stated range covers the measured number.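

In this assay, a second acetyl on the amide-type nitrogen gives a 1.4-fold higher number from compound 2 to compound 3 (0.14 log units; within the scatter), so the two numbers cannot be told apart. Among these compounds, this is the first look at that nitrogen: replacing the amide hydrogen with acetyl, which turns acetamido into diacetylamino, leaves no readable change in this cell assay, whereas the earlier step changed only the aromatic group and left the nitrogen untouched. No measurement shown offers a reason for this result.

The compounds shown leave open how a free amine, a propanoyl chain or a methyl group on that nitrogen would read. From the compounds shown here alone, it also remains open whether the same acetyl change would matter with the 3,4-dimethoxyphenyl group of compound 1, whose result is only a limit.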